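Truncating the biaryl of compound 2 to a methoxy

The source may hold more compounds than are shown below. What is called first, only, known or untested is meant among the compounds shown, and "the series" means these compounds.

The series is followed in a functional assay on DLD-1 cells (Homo sapiens) for antiproliferative activity, read by CellTiter-Glo, with a stated time of 72 h; a higher number here means a weaker inhibitor, a lower number a stronger inhibitor. Compound 2 `Cc1cc(C)cc(-c2cccc(S(=O)(=O)N3CCC(N4CCC(C)CC4)CC3)c2)c1` gives 41 nM in this assay, the lower of the two numbers obtained so far. Among the measured compounds shown here, compound 1 `Cc1ccc(-c2ccccc2S(=O)(=O)N2CCC(N3CCC(C)CC3)CC2)cc1` gives 366 nM in this assay, a higher number than compound 2 by a margin beyond the scatter; the two compounds differ in more than one place, so no single step connects them, and only the two values themselves can be set side by side.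

Compound 3 `COc1cccc(S(=O)(=O)N2CCC(N3CCC(C)CC3)CC2)c1` is the unmeasured member. It differs from compound 2 in one place: methoxy in place of 3,5-dimethylphenyl on an aromatic carbon. For the measured compounds named here, no measured pair isolates a change of this kind, so the expectation rests on the values of compound 2 and compound 1 and on the change itself. The change takes away a whole six-membered aromatic ring of carbon only and puts a methoxy in its place; the step of a 37-fold higher number from compound 2 to compound 3 (1.56 log units; beyond the scatter) is expected to run toward a higher number, by a size well beyond the scatter. For compound 3 the estimate in this assay is 1500 nM, within 400 nM to 8000 nM.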

Compound 3, half-maximal inhibitory concentration: > 5000 nM
Compound 3 ended at the assay's limit (the forecaster's own chance of this, stated with the estimate: 10%); at least 3.3-fold (0.52 log units) between middle value and limit.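

Methoxy in place of 3,5-dimethylphenyl, on an aromatic carbon meta to a large group, gives an at least 120-fold higher number from compound 2 to compound 3 (2.08 log units; beyond the scatter) in this assay, the first step in these notes that isolates a single place. Compound 3 stands at > 5000 nM, which is a limit of the assay and not a number, so the printed size of the step is a floor and the true value of compound 3 stays unknown: the limit of > 5000 nM in this assay, at which 1 of the 3 values shown sits.

The earlier compounds shown here could not show what this pair shows: with the 3,5-dimethylphenyl at this place, compound 2 has a value in the measurable range, and with methoxy there, compound 3 does not.

The pair changes several things at once, so it leaves open whether the loss follows from removing the aromatic ring, from removing its two methyl groups, or from introducing the methoxy oxygen. An unsubstituted phenyl, a cyclohexyl ring or a plain hydrogen at this place would bear on that question, and the compounds shown give no reading for any of them.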